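The compounds below may be only part of what the source reports. "The series", "measured", "known", "first", "only" and "open" are said of these compounds alone.

Series notes. Compound 1 `CC/C=C/[C@H]1C[C@](O)(CC)[C@@H]([C@]2(CC)OC(=O)C[C@@H]2O)[C@@H]1C`, compound 2 `CCCCC(C)Cc1cc(CC)c(CC(=O)O)o1` and compound 3 `CCCCC(C)C/C(=C/[C@@]1(CC)OC(=O)C[C@@H]1O)CC` have been run in a functional assay on Bel-7402 cells (Homo sapiens) for cytotoxicity, read by MTT assay, with a stated time of 72 h; a higher number here means a weaker inhibitor, a lower number a stronger inhibitor. Compound 1 returns only a limit, > 100000 nM. Compound 2 likewise returns only a limit, > 100000 nM. Compound 3 also sits at a limit, > 100000 nM. Compound 3 therefore stands nowhere distinct on the numbers shown: every value rests at the limit of > 100000 nM in this assay, at which 3 of the 3 values shown sit, and no step between measured compounds can be read. Compound 4 `CCCCC(C)C/C(=C\[C@@]1(CC)OC(=O)C[C@@H]1O)CC` is next, differing from compound 3 as follows: the two compounds have the same atoms and bonds; at least one stereo element is drawn with a configuration in one of them and without one in the other: 1 of 4 stereo elements differ; a double bond is drawn E in compound 3 and Z in compound 4. Among the compounds with values here, no measured pair shows the size of such a change here. The expected step that the limit leaves unreadable from compound 3 to compound 4 in this assay is none beyond the scatter. Compound 4 is accordingly expected to give 150000 nM, between 50000 nM and 400000 nM, most likely again only a limit.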

Compound 4, half-maximal inhibitory concentration: > 100000 nM
Compound 4: only a limit was reported (the forecaster's own chance of this, stated with the estimate: 85%); the middle value does not contradict the limit.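

No step can be read between compound 3 and compound 4, drawn E and Z at the double bond, since both sit at a limit: the limit of > 100000 nM in this assay, at which 4 of the 4 values shown sit.

The compounds shown leave open whether any member of this series gives a measurable value in this assay.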